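Benzothiazole amide series: dropping the ring fluorine

The source may report more compounds than this note shows. Statements on the series, on what has been measured and on what is new or still open speak of the compounds shown alone.

Measured so far in a functional assay on ACHN cells (Homo sapiens) for cytotoxicity, read by MTT assay, with a stated time of 48 h; on this read-out higher numbers stand for weaker inhibition and lower numbers for stronger inhibition:
- compound 1 `COc1ccc(-c2cc(C(=O)Nc3nc4ccc(Cl)cc4s3)nc3cc(-c4ccccc4)nn23)cc1`: 7240 nM
- compound 2 `COc1ccc(-c2cc(C(=O)Nc3nc4ccc(F)cc4s3)nc3cc(-c4ccccc4)nn23)cc1`: 39300 nM
- compound 3 `COc1cc(-c2cc(C(=O)Nc3nc4ccc(F)cc4s3)nc3cc(-c4ccccc4)nn23)cc(OC)c1OC`: 32400 nM

Compound 2 sits at the high end of the three numbers in this assay. Its neighbour is compound 3, where the change to compound 3 gives a 1.2-fold lower number from compound 2 to compound 3 (0.08 log units; within the scatter), so the two cannot be separated. Compound 1 lies apart: the halogen swap from compound 1 to compound 2 gives a 5.4-fold higher number from compound 1 to compound 2 (0.73 log units; beyond the scatter), a clear shift toward weaker inhibition.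

The next step, to compound 4 `COc1ccc(-c2cc(C(=O)Nc3nc4ccccc4s3)nc3cc(-c4ccccc4)nn23)cc1`, removes the halogen altogether: hydrogen in place of fluoro on an aromatic carbon. For the measured compounds named here, no measured pair in this set removes a ring halogen outright; the only step that bears on it is the chloro-to-fluoro swap, which showed that the identity of this substituent moves the number by a modest amount. Going from fluoro to hydrogen is a smaller structural change than chloro to fluoro, and with no direct precedent the expectation is a step from compound 2 to compound 4 of a 1.1-fold lower number from compound 2 to compound 4 (0.05 log units; within the scatter) in this assay, not clearly beyond the scatter in either direction. Compound 4 is therefore estimated at 35000 nM, with a plausible range of 12000 nM to 100000 nM.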

Compound 4, half-maximal inhibitory concentration: 1690 nM
For compound 4 the middle estimate is 21-fold (1.32 log units) above the measured one, and the stated range ends above it.
By their numbers in this assay, from the lowest: compound 4; then compound 1; then compounds 3 and 2 (each within the scatter of the next).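

In this assay, taking the halogen off the 1,3-benzothiazol-2-yl group lowers the number whichever halogen leaves: there is a 23-fold lower number from compound 2 to compound 4 (1.37 log units; beyond the scatter), and a 4.3-fold lower number from compound 1 to compound 4 (0.63 log units; beyond the scatter). The earlier compounds shown here compared only chloro with fluoro, so they showed that the choice of halogen matters here but not how either halogen compares with an unsubstituted ring carbon. Among compounds 1, 2 and 4, which differ only at this position, hydrogen now gives the lowest number, and both halogens lie on the side of weaker inhibition, with fluoro furthest from hydrogen; nothing at hand accounts for this order.

Going by these compounds, it remains open whether removing the fluoro group gives a similar step when 3,4,5-trimethoxyphenyl replaces 4-methoxyphenyl, since compound 3 has no partner in this set that differs from it only by that removal. Also open, on these data alone, is how non-halogen groups at this position, such as methyl, nitrile or an amine, would compare with hydrogen, and so whether the low number of compound 4 is specific to the bare ring carbon or extends beyond it.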